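Piperidinyloxy in place of methylpiperazinylmethyl on a shared core

A few compounds are considered here, and "the series" means these few. Any claim that something is new, unique, unknown or untested is made for them only; others in the source may bear on it.

The study examines two measured compounds and one awaiting measurement, all built on one shared core. Compound 1 `Cc1cc(Cl)cc(-c2ccnc3cc(CN4C(=O)CCC4=O)sc23)c1CN1CCNC[C@@H]1C` is tested in an assay on isolated protein for inhibition of ubiquitin carboxyl-terminal hydrolase 7 (Homo sapiens), read by fluorescence, with stated times of 30 min and 1 h (on this read-out higher numbers stand for weaker inhibition and lower numbers for stronger inhibition), and gives 6.6 nM. Compound 2 `Cc1cc(Cl)cc(-c2ccnc3cc(CN4C(=O)C5C(C4=O)C5(C)C)sc23)c1NC1CCCNC1` gives 0.78 nM in this assay. Going by the values given here, of the two numbers so far, compound 1 has the higher one, and compound 2 lies at a lower number, a gap beyond the usual scatter; no step between them is counted, since they differ in more than one place.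

Compound 3 `Cc1cc(Cl)cc(-c2ccnc3cc(CN4C(=O)CCC4=O)sc23)c1OC1CCNCC1` differs from compound 1 in a single place: (piperidin-4-yl)oxy in place of (2-methylpiperazin-1-yl)methyl on an aromatic carbon. The group that enters sits on the same aromatic carbon, ortho to a large group, ortho to a methyl group and para to a chloro group. Among the compounds with values here, no measured pair shows this exchange on its own, so its size is not known from the data. The account expects a step from compound 1 to compound 3 of a 1.7-fold lower number from compound 1 to compound 3 (0.22 log units; within the scatter), which is within the scatter and in no clear direction. Compound 3 is therefore estimated at 4 nM in this assay, with a range from 1.2 nM to 14 nM.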

Compound 3, half-maximal inhibitory concentration: 8 nM
Compound 3: middle estimate off by 2.0-fold (0.30 log units), on the low side, and the stated range covers the measured number.
By their numbers in this assay, from the lowest: compound 2; then compounds 1 and 3 (each within the scatter of the next).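

In this assay, going by these compounds alone, exchanging the (2-methylpiperazin-1-yl)methyl group of compound 1 for the (piperidin-4-yl)oxy group of compound 3 gives a 1.2-fold higher number from compound 1 to compound 3 (0.08 log units; within the scatter), the first reading of a single exchange on this aromatic carbon, ortho to a large group and to a methyl group and para to a chloro group. The two numbers cannot be told apart, so on this core the read-out does not separate these two groups, although the entering group has one heavy atom fewer, swaps a ring with two hetero atoms for a ring with one, brings an oxygen, and lacks the defined stereocentre. No measurement at hand explains why these two groups read alike.

The compounds shown leave open whether a simpler group on this carbon, such as methoxy, or a carboxylic acid would also read alike. From the compounds shown here alone, it also remains open how the (piperidin-4-yl)oxy group would read on the rest of compound 2, which differs from compound 3 in more than one place and so cannot be set against this exchange.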